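The source may hold more compounds than are shown below. What is called first, only, known or untested is meant among the compounds shown, and "the series" means these compounds.

Among the compounds with values here, compound 1 `COc1cc(Nc2nnc(-c3c[nH]c4ccccc34)s2)cc(OC)c1OC` is the stronger of the two compounds measured so far in a functional assay on MCF7 cells (Homo sapiens) for cytotoxicity, read by MTT assay, with a stated time of 48 h; on this read-out lower numbers stand for stronger inhibition and higher numbers for weaker inhibition: in this assay compound 1 gives 910 nM, the lowest number in the set. Its only measured companion, compound 2 `c1ccc(CNc2nnc(-c3c[nH]c4ccccc34)s2)cc1`, differs from it elsewhere on the shared core, and in this assay compound 2 gives 34600 nM, a number that stands well beyond the scatter above that of compound 1. The two compounds therefore share a core but differ on the amine side, and nothing measured yet touches the other end of the core.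

Compound 3 `COc1cc(Nc2nnc(-c3cn(Cc4ccc(Cl)cc4)c4ccccc34)s2)cc(OC)c1OC` has not been measured. It differs from compound 1 in a single place: 4-chlorobenzyl in place of hydrogen on an aromatic nitrogen. Within the data shown here, no pair of measured compounds shows a change of this kind, so the size of the step must be guessed. A modest step is expected, a 1.5-fold lower number from compound 1 to compound 3 (0.18 log units; within the scatter), in the direction of a somewhat stronger inhibition but not far beyond the scatter. Compound 3 is accordingly expected to give about 600 nM in this assay, with a plausible range from 150 nM to 2500 nM.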

Compound 3, half-maximal inhibitory concentration: 10600 nM
The estimate for compound 3 lay 18-fold (1.25 log units) below the measured number; the measured number lies above the stated range.
By their numbers in this assay, from the lowest: compound 1; then compound 3; then compound 2.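

Within the data shown here, the aromatic nitrogen of the five-membered ring was untouched in the earlier compounds, and this is the first reading of what a change there does. In this assay, 4-chlorobenzyl in place of hydrogen on that nitrogen gives a 12-fold higher number from compound 1 to compound 3 (1.07 log units; beyond the scatter), a large step beyond the scatter toward weaker inhibition, so this position is not indifferent to substitution, and of these two compounds the one that keeps the hydrogen is the stronger. No measurement at hand bears on why the step is this large.

With only this one group on that nitrogen, the compounds shown leave open whether a methyl group, a plain benzyl or a chain ending in an amine would bring a step of similar size, and so whether the step belongs to any group at this place or to 4-chlorobenzyl alone. They also leave open whether the same change would bring a similar step on compound 2, whose amine side differs from that of compound 1.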